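Swapping the pyridyl for methylsulfanyl on compound 1

The source may report more compounds than this note shows. Statements on the series, on what has been measured and on what is new or still open speak of the compounds shown alone.

Compound 1 `O=C(CCc1ccc(-c2ccccc2)cc1)c1ncc(-c2ccncc2)o1`: 2.3 nM
Compound 2 `CN(C)C(=O)c1cnc(C(=O)CCc2ccc(COc3ccccc3)cc2)o1`: 6.7 nM
Compound 3 `NC(=O)c1ccc(-c2cnc(CCCc3ccc(-c4ccccc4)cc3)o2)nc1`: 30000 nM

Of the compounds shown here, three have been measured in an assay for inhibition of Fatty-acid amide hydrolase 1 (Rattus norvegicus); on this read-out lower numbers stand for stronger inhibition and higher numbers for weaker inhibition. Compound 1 gives the lowest number of the three, 2.3 nM. Compound 2 comes nearest with 6.7 nM, a gap beyond the scatter. Compound 3, which carries no carbonyl between the chain and the core, lies far away at 30000 nM. Within the data shown here, no two of the measured compounds differ in a single place, so no counted step between them is available.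

Compound 4 `CSc1cnc(C(=O)CCc2ccc(-c3ccccc3)cc2)o1` has not been measured. Compared with compound 1 it shows the change (methylsulfanyl in place of pyridin-4-yl on an aromatic carbon). Among the measured compounds shown here, the data hold no pair that isolates such a change, so the direction rests on the general picture that the larger aromatic group sits on the most potent compound. A loss of potency beyond the scatter is expected, with the step from compound 1 to compound 4 estimated at an 11-fold higher number from compound 1 to compound 4 (1.04 log units; beyond the scatter). Compound 4 is therefore estimated at 25 nM, with a range from 6 nM to 120 nM.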

Compound 4, inhibition constant: 3 nM
Beside the measured number, compound 4's estimate is 8.3-fold (0.92 log units) above it, outside the stated range (below it).
By their numbers in this assay, from the lowest: compounds 1 and 4 (each within the scatter of the next); then compound 2; then compound 3.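

In this assay, methylsulfanyl in place of pyridin-4-yl gives a 1.3-fold higher number from compound 1 to compound 4 (0.12 log units; within the scatter), so on this aromatic carbon, next to the ring oxygen, the six-membered aromatic ring can go without a change that the read-out separates from the scatter. The entering group has 2 heavy atoms against 6 for the group that leaves, and no ring, so a ring at this place is not needed for a number this low on the core of compound 1. Nothing at hand gives a reason why the two groups read alike.

The compounds shown leave open whether an amine, a carboxylic acid or a longer chain such as ethylsulfanyl would read the same at this place. They also leave open whether methylsulfanyl would match pyridin-4-yl with a different chain on the shared core.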